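Chloro to ethyl on compound 3: outlook for compound 4

A few compounds are considered here, and "the series" means these few. Any claim that something is new, unique, unknown or untested is made for them only; others in the source may bear on it.

Three amides sharing one core have been measured in an assay on membranes from Cerebral cortex for displacement of a labelled ligand from Neuronal acetylcholine receptor; alpha4/beta2 (Rattus norvegicus); on this read-out lower numbers stand for stronger inhibition and higher numbers for weaker inhibition. Compound 1 `O=C(Nc1ccc(Cl)cc1)c1cncc(N2CC3CC(C2)N3)c1` gives 0.404 nM. Compound 2 `O=C(Nc1ccccc1)c1cncc(N2CC3CC(C2)N3)c1`, lacking the chloro, gives 1.1 nM; the step of a 2.7-fold higher number from compound 1 to compound 2 (0.44 log units; beyond the scatter) is modest. Compound 3 `O=C(Nc1cccc(Cl)c1)c1cncc(N2CC3CC(C2)N3)c1` gives 0.042 nM and stands lowest of the three, ahead of compound 1 by a 9.6-fold lower number from compound 1 to compound 3 (0.98 log units; beyond the scatter) and of compound 2 by a 26-fold lower number from compound 2 to compound 3 (1.42 log units; beyond the scatter).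

Compound 4 `CCc1cccc(NC(=O)c2cncc(N3CC4CC(C3)N4)c2)c1` is not yet measured. Against compound 3 the difference is ethyl in place of chloro on an aromatic carbon; the same difference, cut one bond further out, reads 3-chlorophenyl to 3-ethylphenyl. Within the data shown here, no measured step exchanges chloro for any group other than hydrogen, so the ethyl case is uncharted. The step of a 26-fold lower number from compound 2 to compound 3 (1.42 log units; beyond the scatter) shows how much of the low number of compound 3 rests on the chloro at this place, while the step of a 2.7-fold higher number from compound 1 to compound 2 (0.44 log units; beyond the scatter) shows a smaller loss when the chloro of compound 1 is removed. Ethyl is expected to retain part of that gain rather than all of it, so a modest rise in the number is expected, a 2.9-fold higher number from compound 3 to compound 4 (0.46 log units; beyond the scatter) in this assay. Compound 4 is estimated at 0.12 nM, with a range from 0.03 nM to 0.5 nM.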

Compound 4, inhibition constant: 1.3 nM
Beside the measured number, compound 4's estimate is 11-fold (1.03 log units) below it, and the stated range ends below it.
By their numbers in this assay, from the lowest: compound 3; then compound 1; then compounds 2 and 4 (each within the scatter of the next).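

In this assay, the step of a 31-fold higher number from compound 3 to compound 4 (1.49 log units; beyond the scatter) is large and about as wide as the gain seen for chloro over hydrogen, so the low number of compound 3 does not carry over to ethyl at this place. The step of a 1.2-fold higher number from compound 2 to compound 4 (0.07 log units; within the scatter) lies within the scatter: compound 2 and compound 4 cannot be told apart, so among the groups shown here, a substituent at this place gives the low number only with chloro, not with ethyl. The step of a 3.2-fold higher number from compound 1 to compound 4 (0.51 log units; beyond the scatter) adds that the 3-ethylphenyl amide also stands apart from the 4-chlorophenyl amide, so a group at this place does not by itself outdo chloro at the other place, and no measurement shown bears on why chloro and ethyl part so widely here.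

Still open, as far as these compounds go, is whether fluoro, bromo or methyl at this place would stand with chloro or with ethyl and hydrogen. A longer chain such as propyl, or an amine, would show whether the number stays at the level of compound 4 or moves further from compound 3.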